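The compounds below may be only part of what the source reports. "The series", "measured", "known", "first", "only" and "open" are said of these compounds alone.

Measured compounds:

- compound 1, `Cc1n[nH]c(C(=O)NS(C)(=O)=O)c1Cc1cccc(-c2ccc(F)cc2)c1`: 3%
- compound 2, `Cc1n[nH]c(C(=O)O)c1Cc1ccc(C#N)cc1`: 85%

Both compounds were tested in an assay on isolated protein for inhibition of 2-Hydroxyacid oxidase 2 (Rattus norvegicus), tested at 10 uM; on this read-out lower numbers stand for a weaker effect and higher numbers for a stronger effect at the one concentration tested. Compound 1 gives 3%, which is the lowest of the two numbers. The nearest number belongs to compound 2, which gives 85%, a difference that lies beyond the scatter of repeated measurements. The two compounds differ in more than one place, so their values cannot be tied to a single change; they only show that compound 2 reaches a far higher reading than compound 1.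

Compound 3, `CNC(=O)c1[nH]nc(C)c1Cc1cccc(-c2ccc(F)cc2)c1`, has not yet been measured. It is derived from compound 1 by a single change: methyl in place of methylsulfonyl on an amide-type nitrogen.

Among the measured compounds shown here, nothing among the measured compounds shows what this particular exchange does on its own. For the measured compounds named here, compound 1 sits at the bottom of the measured range, leaving little room for a further drop, and no measured pair supports a rise. The step from compound 1 to compound 3 is therefore expected to be small, a number 2 percentage points higher from compound 1 to compound 3 (within the scatter), and not beyond the scatter. Compound 3 is expected to give about 5%, within a range from 0% to 25%.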

Compound 3, a percentage reported as inhibition, at one concentration (the size of the read-out at that concentration, not a potency): 53%
For compound 3 the middle estimate is 48 percentage points below the measured one; measured number above the stated range.
By their numbers in this assay, from the lowest: compound 1; then compound 3; then compound 2.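

In this assay, methyl in place of methylsulfonyl on the amide-type nitrogen gives a number 50 percentage points higher from compound 1 to compound 3 (beyond the scatter). The rest of the molecule is the same in both compounds, so this one exchange is enough to lift the reading from near the bottom of the measured range to a clearly higher level, and the shared core with its fluorine-bearing side group does not by itself hold the reading low. The substituent on this nitrogen therefore matters greatly in this series, although no measurement shown here explains why the exchange has so large an effect.

The compounds shown leave open how other groups on this nitrogen would read, such as an ethyl group, a longer chain, an acetyl group or a plain hydrogen, and so whether methyl is a good choice or merely one of many that work. Going by these compounds, compound 2 carries a carboxylic acid but differs from compound 3 in more than one place, so what the acid would do on the core of compound 3 also remains open.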